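Swapping isopropyl for diethylamino on a sulfonyl sulfur

The source may hold more compounds than are shown below. What is called first, only, known or untested is meant among the compounds shown, and "the series" means these compounds.

Measured so far in an ADME assay on microsomes from liver (Homo sapiens) for metabolic stability, read by LC-MS, with a stated time of 60 min, tested at 10 uM; a higher number here means that the compound lasts longer, a lower number that the compound disappears faster:
compound 1 `CCN(CC)S(=O)(=O)c1ccc(S(=O)(=O)N2CCC[C@@H](C(=O)NC3COC3)C2)cc1`: 0.308 h
compound 2 `CC(C)c1noc(C2CCN(C(=O)[C@@H]3CCCN(S(=O)(=O)c4ccc(S(=O)(=O)C(C)C)cc4)C3)CC2)n1`: > 1 h
compound 3 `CC(C)c1noc(N2CCN(C(=O)[C@@H]3CCCN(S(=O)(=O)c4ccc(S(=O)(=O)C(C)C)cc4)C3)CC2)n1`: > 1 h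

Compound 3 stands at the limit of > 1 h in this assay, at which 2 of the 3 values shown sit; its value is a limit of this assay, not a number. Compound 1 gives a plain number in this assay. Compound 4 `CCN(CC)S(=O)(=O)c1ccc(S(=O)(=O)N2CCC[C@@H](C(=O)N3CCN(c4nc(C(C)C)no4)CC3)C2)cc1` differs from compound 3 in one place: diethylamino in place of isopropyl on a sulfonyl sulfur. Among the compounds with values here, no measured pair isolates this change, so the expected step in this assay rests on little. A drop is expected from compound 3 to compound 4, an at least 1.2-fold lower number from compound 3 to compound 4 (0.09 log units; that floor lies within the scatter), possibly beyond the scatter, though a limit is again possible. Compound 4 is expected at 0.8 h, between 0.3 h and 2 h.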

Compound 4, half-life: 0.0283 h
Beside the measured number, compound 4's estimate is 28-fold (1.45 log units) above it, outside the stated range (below it).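

In this assay, diethylamino in place of isopropyl on a sulfonyl sulfur gives an at least 35-fold lower number from compound 3 to compound 4 (1.54 log units; beyond the scatter), a large step beyond the scatter from a change in one place alone. This shows that the group on this sulfonyl sulfur can strongly affect the half-life. The full size of the step cannot be read, since the starting value is a limit of the assay: the limit of > 1 h in this assay, at which 2 of the 4 values shown sit.

The compounds shown leave open whether the fall follows from the nitrogen on the sulfur or from the ethyl chains. A dimethylamino or a cyclopropyl group at this place could separate the two.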